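Silyl-protected tetrahydropyran esters: antiproliferative working notes

A few compounds are considered here, and "the series" means these few. Any claim that something is new, unique, unknown or untested is made for them only; others in the source may bear on it.

Measured compounds:
compound 1 `CC(C)(C)[Si](C)(C)OC[C@H]1OCCC[C@H]1O[Si](C)(C)C(C)(C)C` gives > 100000 nM
compound 2 `CC(C)(C)[Si](C)(C)O[C@@H]1CCCO[C@@H]1CO` gives > 100000 nM
compound 3 `CC(C)(C)[Si](C)(C)O[C@@H]1CCCO[C@@H]1CC(=O)OCc1ccccc1` gives 23000 nM

In a functional assay on A2780 cells (Homo sapiens) for antiproliferative activity, read by sulforhodamine B assay, with a stated time of 48 h (on this read-out higher numbers stand for weaker inhibition of growth and lower numbers for stronger inhibition of growth), compound 1 gives > 100000 nM, which is a limit of the assay and not a number. Compound 2 gives > 100000 nM, again a limit rather than a number. Among the compounds with values here, compound 3 gives 23000 nM, the only real number in the set; the rest of the picture is set by the limit of > 100000 nM in this assay, at which 2 of the 3 values shown sit.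

Compound 2 arises from compound 1 by a hydrogen atom in place of a group of 7 heavy atoms (6 carbon, 1 silicon; no ring), on an oxygen on a saturated carbon. The step that the two limits leave unreadable from compound 1 to compound 2 cannot be sized, since both ends are limits.

Compound 4 `O=C(C[C@H]1OCCC[C@H]1O)OCc1ccccc1` has not been measured. It arises from compound 3 by a hydrogen atom in place of a group of 7 heavy atoms (6 carbon, 1 silicon; no ring), on an oxygen on a saturated carbon. This is the same kind of change as that from compound 1 to compound 2, but not the same: the place differs, the oxygen sitting on a saturated carbon whose other neighbour is a saturated chain carbon in compound 1, and a saturated ring carbon in compound 3. How the core of compound 3 differs from the core of compound 1 is not broken down here.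

Because a step that the two limits leave unreadable from compound 1 to compound 2 cannot be sized, the expectation for compound 4 rests on compound 3 alone, which gives 23000 nM in this assay. The change is expected to weaken the inhibition of growth, by an estimated 2.6-fold higher number from compound 3 to compound 4 (0.42 log units; beyond the scatter). Compound 4 is therefore expected at 60000 nM, estimated to fall between 20000 nM and 200000 nM, with a real chance that only a limit is reported.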

Compound 4, concentration for 50% growth inhibition: > 100000 nM
Compound 4: no number, only a limit; the forecaster's own chance of this, stated with the estimate: 45%; middle value at least 1.6-fold (0.22 log units) from the limit.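

On the core of compound 3, a hydrogen atom in place of the silicon-bearing group of 7 heavy atoms, on an oxygen on a saturated carbon, gives an at least 4.3-fold higher number from compound 3 to compound 4 (0.63 log units; beyond the scatter) in this assay; this step lies beyond the scatter, but it marks only a minimum, as compound 4 gives a limit of the assay and not a number. The same kind of change from compound 1 to compound 2 cannot be read, as both ends are limits, so the series offers no second size to set beside the first, and it neither supports nor contradicts the change carrying over from one core to the other. What stands is a loss of measurable growth inhibition on one core only, and the set has little room to show more: the limit of > 100000 nM in this assay, at which 3 of the 4 values shown sit.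

Going by these compounds, it remains open whether a small group on that oxygen, such as a methyl ether or an acetyl ester, would keep the inhibition seen with compound 3, or whether the silicon-bearing group is specifically needed. Also open, on these data alone, is how a carboxylic acid or an amide would fare in place of the benzyl ester of compound 3.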